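This account rests on a few compounds, and the source may have more. Where it says the series, first, only, none or still open, it means among the compounds named here.

Measured compounds: compound 1 `Nc1nc(Cl)c(-c2cccs2)c(N[C@@H]2C[C@H](CO)[C@@H](O)[C@H]2O)n1`, compound 2 `Nc1nc(Cl)c(-c2nccs2)c(N[C@@H]2C[C@H](CO)[C@@H](O)[C@H]2O)n1`, compound 3 `CCNc1nc(C)c(-c2nc3ccccc3s2)c(N[C@@H]2C[C@H](CO)[C@@H](O)[C@H]2O)n1`. In an ADME assay on cells (Homo sapiens) for cytotoxicity, read by polymerase chain reaction, with a stated time of 3 days (on this read-out lower numbers stand for higher toxicity in this test and higher numbers for lower toxicity in this test), compound 1 gives > 25000 nM, a limit of the assay. In this assay compound 2 gives > 25000 nM, likewise a limit. In this assay compound 3 gives 12000 nM.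

Compound 3 is thus the only one of the three with a number rather than a limit in this assay; the other two sit at the limit of > 25000 nM in this assay, at which 2 of the 3 values shown sit. For the measured compounds named here, the single measured step, a step that the two limits leave unreadable from compound 1 to compound 2, lies between two limits and concerns a different part of the molecule. Compound 4 `Cc1nc(NCC2CCC2)nc(N[C@@H]2C[C@H](CO)[C@@H](O)[C@H]2O)c1-c1nc2ccccc2s1` differs from compound 3 by cyclobutyl in place of methyl on a saturated chain carbon bound to a nitrogen on an aromatic ring. Going by the values given here, no measured step bears on this change, so no shift beyond the scatter is expected in this assay; the estimated step is no change at the digits printed from compound 3 to compound 4 (within the scatter). Compound 4 is expected at 12000 nM, within 4000 nM to 36000 nM.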

Compound 4, half-maximal cytotoxic concentration: > 25000 nM
Compound 4: a limit, no number (the forecaster's own chance of this, stated with the estimate: 30%); middle value at least 2.0-fold (0.31 log units) from the limit.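

In this assay, for the compounds shown here, the first readable step at this position is an at least 2.0-fold higher number from compound 3 to compound 4 (0.31 log units; beyond the scatter), for cyclobutyl in place of methyl on a saturated chain carbon bound to a nitrogen on an aromatic ring. Compound 4 gives > 25000 nM, a limit and not a number, so the step has a floor but no readable size. Compound 3 remains the only compound with a number: the limit of > 25000 nM in this assay, at which 3 of the 4 values shown sit.

On these data alone, whether the ring itself matters stays open, since a longer open chain in place of cyclobutyl would be needed to tell. As far as these compounds go, how an amine or a carboxylic acid at this place would read in this assay also stays open.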